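From 4-chlorophenyl to 2-cyanophenyl on an amide nitrogen

This account rests on a few compounds, and the source may have more. Where it says the series, first, only, none or still open, it means among the compounds named here.

Compounds measured in an ADME assay on MT4 cells (Homo sapiens) for cytotoxicity, read by MTT assay, with a stated time of 5 days; on this read-out lower numbers stand for higher toxicity in this test and higher numbers for lower toxicity in this test:
- Compound 1 `COc1cc2nc(Nc3ccc(C#N)cc3)nc(Nc3c(C)cc(/C=C/C#N)cc3F)c2cc1OC`: > 52000 nM, a limit of the assay
- Compound 2 `COc1cc2nc(SCC(=O)Nc3cccc(Cl)c3)nc(Nc3c(Cl)cc(/C=C/C#N)cc3Cl)c2cc1OC`: > 208000 nM, a limit of the assay
- Compound 3 `COc1cc2nc([S+]([O-])CC(=O)Nc3ccc(Cl)cc3)nc(Nc3c(Cl)cc(/C=C/C#N)cc3Cl)c2cc1OC`: 14400 nM, a measured number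

Compound 3 is the only one of the three with a measured number, as the other two entries are limits. In this assay, compound 3 gives 14400 nM. Going by the values given here, its position relative to the other two compounds rests on those limits alone, and no pair among the three differs in just one place.

Compound 4 `COc1cc2nc([S+]([O-])CC(=O)Nc3ccccc3C#N)nc(Nc3c(Cl)cc(/C=C/C#N)cc3Cl)c2cc1OC` has not yet been measured. It departs from compound 3 at a single place: 2-cyanophenyl in place of 4-chlorophenyl on an amide-type nitrogen. In words, 2-cyanophenyl stands in place of 4-chlorophenyl on an amide-type nitrogen.

Among the compounds with values here, no measured pair shows what this kind of exchange does, so the expectation starts from compound 3 at 14400 nM. A small move toward lower toxicity in this test is expected, and it may not exceed the usual scatter. The estimated step is a 1.4-fold higher number from compound 3 to compound 4 (0.14 log units; within the scatter). For compound 4, the estimated value in this assay is 20000 nM, with an expected range from 7000 nM to 60000 nM.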

Compound 4, half-maximal cytotoxic concentration: > 206000 nM
Compound 4 was reported as a limit (the forecaster's own chance of this, stated with the estimate: 25%); middle value at least 10-fold (1.01 log units) from the limit.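

This is the first exchange among the compounds shown that can be read at a single place: in this assay, 2-cyanophenyl in place of 4-chlorophenyl on an amide-type nitrogen gives an at least 14-fold higher number from compound 3 to compound 4 (1.15 log units; beyond the scatter). Going by these compounds alone, the group on this nitrogen is therefore enough by itself to move the read-out beyond the usual scatter, toward lower toxicity in this test, with the rest of the structure unchanged, which the earlier compounds could not show as no two of them differed in just one place. The entry for compound 4 is a limit of the assay and not a number: the limit of > 206000 nM in this assay, at which 1 of the 4 values shown sits.

The exchange removes the chlorine, brings in the nitrile and changes the place of the substituent on the ring all at once, and the compounds shown do not tell which of these carries the step. They also leave open how this read-out would respond to 2-chlorophenyl or 4-cyanophenyl on the same nitrogen, which would separate those changes, or to an unsubstituted phenyl group there.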